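A Fluoro Added to the Core of Compound 1

A few compounds are considered here, and "the series" means these few. Any claim that something is new, unique, unknown or untested is made for them only; others in the source may bear on it.

Among the measured compounds shown here, in an ADME assay (liver) for metabolic stability, with Liver microsome (Homo sapiens) as the target, using microsomes (a higher number here means faster removal of the compound, a lower number slower removal), compound 1 (`Fc1ncccc1[C@H](Nc1nnc(-c2c[nH]c3ncccc23)o1)C1CC1`) gives 21 mL.min-1.g-1 and stands level with the only other measured compound. That compound, compound 2 (`Fc1cnccc1[C@H](Nc1nnc(-c2c[nH]c3ncccc23)o1)C1CC1`), gives 27 mL.min-1.g-1 in this assay and cannot be told apart from compound 1 on these numbers. The two differ by 3-fluoropyridin-4-yl in place of 2-fluoropyridin-3-yl, and the measured change, a 1.3-fold higher number from compound 1 to compound 2 (0.11 log units; within the scatter), stays within the scatter.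

Compound 3 (`Fc1cnc2[nH]cc(-c3nnc(N[C@@H](c4cccnc4F)C4CC4)o3)c2c1`) departs from compound 1 at a different place: fluoro in place of hydrogen on an aromatic carbon. This is fluoro in place of hydrogen on an aromatic carbon of the six-membered aromatic ring with 1 nitrogen, part of a fused or bridged system of two rings. For the measured compounds named here, no measured step touches that place, so the single step available, a 1.3-fold higher number from compound 1 to compound 2 (0.11 log units; within the scatter), bears on it only indirectly. It gives no sign of a large move, but two compounds offer thin evidence, and the range is kept wide. The expected change is a 1.1-fold lower number from compound 1 to compound 3 (0.02 log units; within the scatter) and so nothing beyond the scatter in this assay is anticipated. The estimate for compound 3 is 20 mL.min-1.g-1 (expected range 10 mL.min-1.g-1 to 38 mL.min-1.g-1).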

Compound 3, intrinsic clearance in microsomes: < 14 mL.min-1.g-1
Compound 3: only a limit was reported (the forecaster's own chance of this, stated with the estimate: 3%); middle value at least 1.4-fold (0.15 log units) away from the limit.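

The earlier step, 3-fluoropyridin-4-yl in place of 2-fluoropyridin-3-yl, touched only the group on the saturated chain carbon and said nothing about the core. Fluoro in place of hydrogen on an aromatic carbon of the six-membered aromatic ring with 1 nitrogen, two atoms from the ring nitrogen, now gives the first reading at this position, an at least 1.5-fold lower number from compound 1 to compound 3 (0.17 log units; that floor lies within the scatter). The floor of that step lies within the scatter, so in this assay the data show only that this single added fluorine brings no rise in the number, not that a real difference exists. The reading for compound 3 is a limit of the assay, not a number: the limit of < 14 mL.min-1.g-1 in this assay, at which 1 of the 3 values shown sits.

As far as these compounds go, whether the true step goes beyond the scatter therefore stays open. Also open, from the compounds shown here alone, is whether chloro, methoxy or a nitrile on the same aromatic carbon would read as fluoro does, and whether the same fluoro on the core of compound 2 would give a like result.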